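From one ester to another: estimating compound 4

This account rests on a few compounds, and the source may have more. Where it says the series, first, only, none or still open, it means among the compounds named here.

Of the compounds shown here, three sharing one core have been tested in a functional assay on MCF7 cells (Homo sapiens) for inhibition, read by MTT assay, with a stated time of 3 days; a higher number here means a weaker inhibitor, a lower number a stronger inhibitor. Compound 1 `COc1cc(-c2nc3ccccc3s2)ccc1OCC(=O)NNC(=O)CN[C@@H](CS)C(=O)O` gives 1230 nM, compound 2 `COc1cc(-c2nc3ccccc3s2)ccc1OCC(=O)NNC(=O)CN(C(C)=O)[C@@H](CS)C(=O)O` gives 1750 nM, and compound 3 `CCOC(=O)[C@H](NCC(=O)NNC(=O)COc1ccc(-c2nc3ccccc3s2)cc1OC)[C@@H](C)CC` gives 2900 nM. Compound 3 stands apart from only one of the other two. The numbers show a 2.4-fold higher number from compound 1 to compound 3 (0.37 log units; beyond the scatter), but also a 1.7-fold higher number from compound 2 to compound 3 (0.22 log units; within the scatter).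

Compound 4 `CCOC(=O)[C@H](CS)N(CC(=O)NNC(=O)COc1ccc(-c2nc3ccccc3s2)cc1OC)C(C)=O` has not yet been measured. On a saturated chain carbon bound to a carbonyl carbon, acetyl(1-(ethoxycarbonyl)-2-sulfanylethyl)amino takes the place of the (1-(ethoxycarbonyl)-2-methylbutyl)amino of compound 3: acetyl(1-(ethoxycarbonyl)-2-sulfanylethyl)amino in place of (1-(ethoxycarbonyl)-2-methylbutyl)amino on a saturated chain carbon bound to a carbonyl carbon.

Within the data shown here, two measured steps bear most directly on this change. Placing acetyl on the amine nitrogen gave a 1.4-fold higher number from compound 1 to compound 2 (0.15 log units; within the scatter). The entering group also closely resembles the acetyl(1-carboxy-2-sulfanylethyl)amino of compound 2, and exchanging that group gave the step already shown, a 1.7-fold higher number from compound 2 to compound 3 (0.22 log units; within the scatter). Neither step goes beyond the scatter, and the largest step in this small set is modest. No shift beyond the scatter is therefore expected in this assay, and the estimated step is a 1.3-fold lower number from compound 3 to compound 4 (0.12 log units; within the scatter). The expected value for compound 4 is 2200 nM, with an estimated range of 1100 nM to 4200 nM.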

Compound 4, half-maximal inhibitory concentration: 1890 nM
The estimate for compound 4 lay 1.2-fold (0.07 log units) above the measured number, within the range that was stated.
By their numbers in this assay, from the lowest: compounds 1, 2, 4 and 3 (each within the scatter of the next, the first and the last beyond it).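

In this assay, ethyl in place of hydrogen on an oxygen next to a carbonyl group gives a 1.1-fold higher number from compound 2 to compound 4 (0.03 log units; within the scatter), so with acetyl on the amine nitrogen, the ethyl ester and the carboxylic acid cannot be told apart in this assay. The larger exchanges at this position also stay small: the step from the (1-(ethoxycarbonyl)-2-methylbutyl)amino group is a 1.5-fold lower number from compound 3 to compound 4 (0.19 log units; within the scatter) and the step from the (1-carboxy-2-sulfanylethyl)amino group is a 1.5-fold higher number from compound 1 to compound 4 (0.19 log units; within the scatter), which places compound 4 within the scatter of both compound 1 and compound 3, even though those two lie beyond the scatter of each other. Nothing measured here explains why these steps are so small. 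

The compounds shown leave open whether a primary amide or a butyl ester in place of the ethyl ester would move the number beyond the scatter. They also leave open what a carboxylic acid would do when paired with the 2-methylbutyl chain of compound 3, or what a longer acyl group, such as butanoyl, would do in place of the acetyl on the nitrogen.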